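The source may report more compounds than this note shows. Statements on the series, on what has been measured and on what is new or still open speak of the compounds shown alone.

Working notes on the series. All three compounds share one core; compound 1 `Cc1nc(-c2cccnc2)sc1-c1nnc(-c2ccccc2)o1` carries a phenyl on it and compound 2 `Cc1nc(-c2cccnc2)sc1-c1nnc(-c2ccc(Cl)cc2)o1` a 4-chlorophenyl. In an ADME assay on HeLa cells (Homo sapiens) for cytotoxicity, read by MTT assay (a higher number here means that more compound is tolerated, a lower number that less compound is tolerated), compound 1 is reported only as a limit, > 100 ug/mL. In this assay compound 2 likewise gives only a limit, > 100 ug/mL. The step that the two limits leave unreadable from compound 1 to compound 2 therefore cannot be read, both ends sitting at the limit of > 100 ug/mL in this assay, at which 2 of the 2 values shown sit. Compound 2 thus stands at a limit of the assay rather than at a number. Compound 3 `Cc1cccc(-c2nnc(-c3sc(-c4cccnc4)nc3C)o2)c1` differs from compound 2 in one place: 3-methylphenyl in place of 4-chlorophenyl on an aromatic carbon. Within the data shown here, the only measured step that bears on this position is the unreadable one just noted, and no measured value leaves the limit. Compound 3 is therefore expected to return a limit again in this assay, the step that the limit leaves unreadable from compound 2 to compound 3 not expected to exceed the scatter. Compound 3 is estimated at 150 ug/mL in this assay, with a range from 70 ug/mL to 400 ug/mL.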

Compound 3, half-maximal cytotoxic concentration: > 100 ug/mL
Compound 3: no number, only a limit (the forecaster's own chance of this, stated with the estimate: 80%); the middle value does not contradict the limit.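

In this assay, among these compounds, compound 3 also gives only a limit, so no step among compound 1, compound 2 and compound 3 can be read: the limit of > 100 ug/mL in this assay, at which 3 of the 3 values shown sit. The compounds shown leave open at what concentration any of them becomes cytotoxic, and whether the 4-chlorophenyl and 3-methylphenyl changes alter it.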